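Piperidine for dimethylamine on a methoxy-bearing quinoxaline dioxide core

A few compounds are considered here, and "the series" means these few. Any claim that something is new, unique, unknown or untested is made for them only; others in the source may bear on it.

Compound 1 `CN(C)CCNc1n[n+]([O-])c2ccccc2[n+]1[O-]` — 200 nM
Compound 2 `[O-][n+]1nc(NCCN2CCCCC2)[n+]([O-])c2ccccc21` — 1100 nM
Compound 3 `COc1ccc2c(c1)[n+]([O-])c(NCCN(C)C)n[n+]2[O-]` — 2900 nM

The three compounds were tested in a functional assay on SiHa cells (Homo sapiens) for cytotoxicity, with a stated time of 4 h; a lower number here means a stronger inhibitor, a higher number a weaker inhibitor. Compound 1 gives 200 nM, compound 2 gives 1100 nM and compound 3 gives 2900 nM in this assay.

Compound 4 `COc1ccc2c(c1)[n+]([O-])c(NCCN1CCCCC1)n[n+]2[O-]` is not yet measured. It differs from compound 3 by piperidin-1-yl in place of dimethylamino on a saturated chain carbon, two bonds along the chain from a nitrogen on an aromatic ring. The same change, made once among the measured compounds, from compound 1 to compound 2, is piperidin-1-yl in place of dimethylamino on a saturated chain carbon, two bonds along the chain from a nitrogen on an aromatic ring, and it gave a 5.5-fold higher number from compound 1 to compound 2 (0.74 log units; beyond the scatter). The two cores differ by methoxy in place of hydrogen on an aromatic carbon, a change that gave a 15-fold higher number from compound 1 to compound 3 (1.16 log units; beyond the scatter).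

Because the step of a 5.5-fold higher number from compound 1 to compound 2 (0.74 log units; beyond the scatter) was made on the core of compound 1, whereas compound 4 carries the core of compound 3, the same change is expected to give roughly a step of a 5.5-fold higher number from compound 3 to compound 4 (0.74 log units; beyond the scatter) in this assay. That rests on a single earlier step and on a core whose own step a 15-fold higher number from compound 1 to compound 3 (1.16 log units; beyond the scatter) is large, so the expectation is held loosely. Compound 4 is therefore estimated at 16000 nM, within 6000 nM to 40000 nM.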

Compound 4, half-maximal inhibitory concentration: 3000 nM
Compound 4: middle estimate off by 5.3-fold (0.73 log units), on the high side; the measured number lies below the stated range.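

On the methoxy-bearing core, piperidin-1-yl in place of dimethylamino gave a 1.0-fold higher number from compound 3 to compound 4 (0.01 log units; within the scatter) and so did not repeat the step seen on the core of compound 1: the same change on two cores in this assay, a 5.5-fold higher number (0.74 log units; beyond the scatter) from compound 1 to compound 2 and a 1.0-fold higher number (0.01 log units; within the scatter) from compound 3 to compound 4, 5.3-fold (0.73 log units) apart, beyond the scatter of two such steps

Read the other way, methoxy in place of hydrogen gave a 2.7-fold higher number from compound 2 to compound 4 (0.44 log units; beyond the scatter) with piperidin-1-yl present, so the size of that step also differed with the amine on the chain: the same change on two cores in this assay, a 15-fold higher number (1.16 log units; beyond the scatter) from compound 1 to compound 3 and a 2.7-fold higher number (0.44 log units; beyond the scatter) from compound 2 to compound 4, 5.3-fold (0.73 log units) apart, beyond the scatter of two such steps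

Across these four compounds the two changes therefore do not add independently, and the size of either one cannot be carried unchanged from one core to the other, but a single pair of cores does not show why the steps differ or how a further core would behave.

The compounds shown leave open whether another amine at the chain end, such as morpholine or pyrrolidine, would also differ between the two cores. They also leave open how a longer chain, or a chloro group in place of methoxy, would behave.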